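The source may hold more compounds than are shown below. What is called first, only, known or untested is meant among the compounds shown, and "the series" means these compounds.

Within the data shown here, compound 2 `COc1ccc(C(=O)Nc2c(C(O)(C(F)(F)F)C(F)(F)F)ccc3ccccc23)cc1` is the one compound with a measured number here: in an assay on LtK cells with ATP-sensitive inward rectifier potassium channel 11 (Homo sapiens) as the target (a lower number here means that less compound is needed, a higher number that more compound is needed for the effect), compound 2 gives 417 nM. Compound 1 `CCCC(C)C(=O)Nc1c(C(O)(C(F)(F)F)C(F)(F)F)ccc2ccccc12` gives only a limit in this assay, > 10000 nM, which is the limit of > 10000 nM in this assay, at which 1 of the 2 values shown sits. The step between them, an at least 23-fold lower number from compound 1 to compound 2 (1.37 log units; beyond the scatter), came from exchanging a short branched chain for an aromatic ring. Compound 3 `O=C(Nc1c(C(O)(C(F)(F)F)C(F)(F)F)ccc2ccccc12)c1cccnc1` differs from compound 2 by pyridin-3-yl in place of 4-methoxyphenyl on a carbonyl carbon. Among the measured compounds shown here, the one measured step does not compare two aromatic rings, so no step beyond the scatter is expected, as a 1.9-fold higher number from compound 2 to compound 3 (0.28 log units; within the scatter). Compound 3 is therefore estimated at 800 nM, within 250 nM to 2500 nM.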

Compound 3, half-maximal effective concentration: 60 nM
Compound 3: middle estimate off by 13-fold (1.12 log units), on the high side, outside the stated range (below it).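

On this carbonyl carbon, one aromatic ring cannot simply stand in for another in this assay: pyridin-3-yl in place of 4-methoxyphenyl gives a 7.0-fold lower number from compound 2 to compound 3 (0.84 log units; beyond the scatter). So the kind of ring matters, not only the presence of one. Against 1-methylbutyl, the change reaches an at least 160-fold lower number from compound 1 to compound 3 (2.22 log units; beyond the scatter), and this is only a bound, as the value of compound 1 is a limit: the limit of > 10000 nM in this assay, at which 1 of the 3 values shown sits.

Still open, on these data alone, is how plain phenyl would compare, which would help separate losing the methoxy group from gaining the ring nitrogen. Pyridin-2-yl and pyridin-4-yl would show whether the nitrogen's location matters.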